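This account rests on a few compounds, and the source may have more. Where it says the series, first, only, none or still open, it means among the compounds named here.

Of the compounds shown here, three of a shared core have been measured in a functional assay on RPMI-8226 cells (Homo sapiens) for inhibition, read by sulforhodamine B assay, with a stated time of 48 h; a lower number here means a stronger inhibitor of growth, a higher number a weaker inhibitor of growth. Compound 1 `O=C(Nc1cccc(-n2cc(-c3ccncc3)c(-c3ccc(Cl)c(O)c3)n2)c1)Nc1ccc(Cl)c(Cl)c1` gives 1030 nM, compound 3 `O=C(Nc1cccc(-n2cc(-c3ccncc3)c(-c3ccc(Cl)c(O)c3)n2)c1)Nc1cc(C(F)(F)F)cc(C(F)(F)F)c1` gives 477 nM, and compound 2 `COc1cc(-c2nn(-c3cccc(NC(=O)c4ccc(Cl)c(C(F)(F)F)c4)c3)cc2-c2ccncc2)ccc1Cl` gives 1620 nM, the highest number of the three, within the scatter of compound 1 but beyond it relative to compound 3. Compound 4 `COc1cc(-c2nn(-c3cccc(NC(=O)Nc4cccc(C(F)(F)F)c4)c3)cc2-c2ccncc2)ccc1Cl` differs from compound 2 by a single change: (3-(trifluoromethyl)phenyl)amino in place of 4-chloro-3-(trifluoromethyl)phenyl on a carbonyl carbon. In its linking group compound 4 resembles compounds 1 and 3 more than compound 2 does, and both of those show lower numbers than compound 2. A modest step to a lower number is therefore expected, a 2.0-fold lower number from compound 2 to compound 4 (0.31 log units; beyond the scatter), perhaps not beyond the scatter. Compound 4 is estimated at 800 nM, within a range from 300 nM to 2500 nM.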

Compound 4, concentration for 50% growth inhibition: 340 nM
The estimate for compound 4 lay 2.4-fold (0.37 log units) above the measured number; measured number inside the range.
By their numbers in this assay, from the lowest: compounds 4 and 3 (each within the scatter of the next); then compounds 1 and 2 (each within the scatter of the next).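

In this assay, for the compounds shown here, (3-(trifluoromethyl)phenyl)amino in place of 4-chloro-3-(trifluoromethyl)phenyl on a carbonyl carbon gives a 4.8-fold lower number from compound 2 to compound 4 (0.68 log units; beyond the scatter), the first step here between compounds differing in one place, so the number responds to the group at this position. The change brings in a nitrogen and one hydrogen-bond donor while removing a chlorine, and this single step cannot separate those parts. Nothing available explains the step. Going by these compounds, it remains open whether the chlorine could be kept alongside the amino link without losing the step. On these data alone, how a methylene or an oxygen link would compare also remains open.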